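This account rests on a few compounds, and the source may have more. Where it says the series, first, only, none or still open, it means among the compounds named here.

Measured compounds:
compound 1 `CC(C)N(Cc1cccc(OCCCCCC(=O)O)c1)C(=O)c1ccc(-c2ccco2)cc1` — > 26000 nM
compound 2 `CC(C)Oc1cccc(-c2ccc(C(=O)N(Cc3cccc(OCCCCCC(=O)O)c3)C(C)C)cc2)c1` — > 26000 nM

In an ADME assay on Raji cells (Homo sapiens) for cytotoxicity, read by CellTiter-Glo and resazurin assay, with a stated time of 72 h (on this read-out higher numbers stand for an effect only at larger amounts of compound and lower numbers for an effect already at smaller amounts), compound 1 gives > 26000 nM, which is a limit of the assay and not a number. In this assay compound 2 likewise gives > 26000 nM, again a limit. Among the compounds with values here, the one measured step, a step that the two limits leave unreadable from compound 1 to compound 2, cannot be sized because of the limit of > 26000 nM in this assay, at which 2 of the 2 values shown sit. Compound 2 therefore stands only at a limit, and no change beyond the scatter is readable between it and compound 1.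

Compound 3 `CC(C)N(Cc1cccc(OCCCCCC(=O)O)c1)C(=O)c1ccc(-c2ccsc2)cc1` is not yet measured. It differs from compound 2 in one place: thiophen-3-yl in place of 3-isopropoxyphenyl on an aromatic carbon. Within the data shown here, the only measured step bears on this change merely by showing that both of its ends sit at the limit, so no size or direction can be taken from it. Compound 3 is consequently expected to stay at the limit as well, with an expected step that the limit leaves unreadable from compound 2 to compound 3 that means no shift beyond the scatter. The estimate for compound 3 in this assay is 40000 nM, expected within 15000 nM to 120000 nM.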

Compound 3, half-maximal effective concentration: > 26000 nM
Compound 3: a limit, no number (the forecaster's own chance of this, stated with the estimate: 80%); the middle value does not contradict the limit.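

Compound 3 sits at the same limit as compound 1 and compound 2, so no step among these three compounds can be read: the limit of > 26000 nM in this assay, at which 3 of the 3 values shown sit. The compounds shown leave open whether any group at this aromatic carbon would give a measurable value on these cells.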